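A phenyl exchange at the edge of the assay

The compounds below may be only part of what the source reports. "The series", "measured", "known", "first", "only" and "open" are said of these compounds alone.

In a toxicity assay on NIH3T3 cells (Mus musculus) for cytotoxicity, read by resazurin assay (a lower number here means that less compound is needed, a higher number that more compound is needed for the effect), compound 3 (`COC(=O)c1ccc(NCc2cncn2Cc2ccc(-c3ccccc3)cc2)cc1`) stands at > 10000 nM as a limit and not a number. Compound 1 (`c1ccc(-c2ccc(Cn3cncc3CNc3ccc(-c4ccccc4)c(-c4ccccc4)c3)cc2)cc1`) shows > 10000 nM as a limit too. Compound 2 (`COC(=O)c1ccc(NCc2cncn2Cc2ccc(-c3ccccc3)cc2)cc1-c1ccccc1`) shows > 1000 nM as a limit as well. None of the three therefore has a measured number.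

Compound 4 (`c1ccc(-c2ccc(Cn3cncc3CNc3ccc(-c4ccccc4)cc3)cc2)cc1`) differs from compound 3 in one place, with phenyl in place of methoxycarbonyl on an aromatic carbon, para to a large group (phenyl in place of methoxycarbonyl on an aromatic carbon).

The closest measured change exchanges the same two groups in the opposite sense, and it is a step that the two limits leave unreadable from compound 1 to compound 2 in size. The other change, hydrogen in place of phenyl on an aromatic carbon, is a step that the two limits leave unreadable from compound 2 to compound 3 in size. Neither gives a direction or a magnitude, so no change beyond the scatter is expected in this assay and the expected step is a step that the limit leaves unreadable from compound 3 to compound 4 in size. For compound 4 the estimated value is 15000 nM with an expected range from 5000 nM to 40000 nM and the read-out will probably be only a limit.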

Compound 4, half-maximal effective concentration: > 10000 nM
Compound 4: no number, only a limit (the forecaster's own chance of this, stated with the estimate: 85%); the middle value lies beyond the limit too.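

In this assay no step can be read from compound 3 to compound 4 or from compound 1 to compound 4, because all three compounds stand at a limit and not a number: the limit of > 10000 nM in this assay, at which 3 of the 4 values shown sit.

The compounds shown leave open how far any of them lies from its limit, and so whether exchanging phenyl, methoxycarbonyl or hydrogen changes the read-out at all.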